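From 2-chlorophenyl to 2-isopropylphenyl

This account rests on a few compounds, and the source may have more. Where it says the series, first, only, none or still open, it means among the compounds named here.

Compound 1 (`CC[C@@H](Nc1c(C#N)c(-c2ccc(-c3cccc(Cl)c3F)cc2)nc2cnccc12)C(N)=O`), compound 2 (`CC[C@@H](Nc1c(C#N)c(-c2ccc(-c3cccc(CO)c3)cc2)nc2cnccc12)C(N)=O`) and compound 3 (`CC[C@@H](Nc1c(C#N)c(-c2ccc(-c3ccccc3Cl)cc2)nc2cnccc12)C(N)=O`) share one core. In a physicochemical assay for lipophilicity, read by HPLC, at pH 7.5 (on this read-out lower numbers stand for lower lipophilicity and higher numbers for higher lipophilicity), compound 1 gives 3.1 and compound 2 gives 2 while compound 3 gives 2.9 on the same scale. Compound 3 thus lies within the scatter of compound 1 and clear of compound 2 (a number 0.90 log units higher from compound 2 to compound 3 (beyond the scatter)).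

Compound 4 (`CC[C@@H](Nc1c(C#N)c(-c2ccc(-c3ccccc3C(C)C)cc2)nc2cnccc12)C(N)=O`) differs from compound 3 (isopropyl in place of chloro on an aromatic carbon): isopropyl in place of chloro on an aromatic carbon, ortho to a large group. Within the data shown here, no measured step exchanges chloro for isopropyl. The steps involving hydroxymethyl are large or modest (a number 1.10 log units lower from compound 1 to compound 2 (beyond the scatter)), and the one without it stays small (a number 0.20 log units lower from compound 1 to compound 3 (within the scatter)). That small step is the nearer guide, and only carbon enters, so a modest rise is expected in this assay (a number 0.40 log units higher from compound 3 to compound 4 (beyond the scatter)). Compound 4 is estimated at 3.3 with 2.9 to 3.7 as its range.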

Compound 4, distribution coefficient: 3.5
Compound 4: the middle estimate sits 0.20 log units below what was measured, and the stated range covers the measured number.
By their numbers in this assay, from the lowest: compound 2; then compounds 3 and 1 (each within the scatter of the next); then compound 4.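

In this assay, among these compounds, isopropyl in place of chloro, ortho to a large group, gives a step beyond the scatter (a number 0.60 log units higher from compound 3 to compound 4 (beyond the scatter)), the first such step among the changes without hydroxymethyl. The 2-isopropylphenyl group also stands clear of 3-chloro-2-fluorophenyl (a number 0.40 log units higher from compound 1 to compound 4 (beyond the scatter)) and of 3-(hydroxymethyl)phenyl (a number 1.50 log units higher from compound 2 to compound 4 (beyond the scatter)), so compound 4 holds the highest of the four numbers. No evidence on hand bears on the origin of these steps.

From the compounds shown here alone, whether a longer chain would extend this rise remains open. Going by these compounds, how an amine or a carboxylic acid at this position would read in this assay also remains open.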